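This account rests on a few compounds, and the source may have more. Where it says the series, first, only, none or still open, it means among the compounds named here.

In a functional assay on HCT-116 cells (Homo sapiens) for inhibition, read by MTT assay, with a stated time of 48 h (a higher number here means a weaker inhibitor, a lower number a stronger inhibitor), two compounds from this series have been measured so far. Compound 1 `COc1ccc(N(C)c2nc(C)nc3ccccc23)cc1OCCC[Se]C#N` gives 852 nM, the higher of the two numbers, which makes it the weaker inhibitor of the pair. Compound 2 `C[Se]c1ccc(N(C)c2nc(C3CC3)nc3ccccc23)cc1` gives 15 nM, and this gap lies well beyond the usual scatter of repeated measurements. Within the data shown here, these two compounds differ in more than one place, however, and no measured pair isolates a single change.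

Compound 3 `COc1ccc(N(C)c2nc(C)nc3ccccc23)cc1C(=O)OCC[Se]C#N` keeps the core of compound 1 and alters one group, on an aromatic carbon of a six-membered aromatic ring of carbon only, ortho to a methoxy group: a group of 8 heavy atoms (4 carbon, 1 nitrogen, 2 oxygen, 1 selenium; no ring) in place of a group of 7 heavy atoms (4 carbon, 1 nitrogen, 1 oxygen, 1 selenium; no ring), on an aromatic carbon. Neither the leaving group nor the entering group has a ring or a net charge, and the entering group adds a double bond.

Compound 1, at 852 nM, is the closest reference for any expectation. The estimated step of a 1.4-fold lower number from compound 1 to compound 3 (0.15 log units; within the scatter) is small, toward a slightly lower number, and is not expected to clear the scatter. Compound 3 is expected at about 600 nM, within an estimated range of 150 nM to 2400 nM.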

Compound 3, half-maximal inhibitory concentration: 951 nM
Compound 3: middle estimate off by 1.6-fold (0.20 log units), on the low side; the measured number falls inside the stated range.
By their numbers in this assay, from the lowest: compound 2; then compounds 1 and 3 (each within the scatter of the next).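

In this assay, among these compounds, placing the group of 8 heavy atoms in place of the group of 7 heavy atoms, on the aromatic carbon ortho to a methoxy group, gives a 1.1-fold higher number from compound 1 to compound 3 (0.05 log units; within the scatter) and so provides the first reading of this position through a single change. The two groups both carry selenium and a nitrile, and the exchange, which brings in a double bond, leaves no difference that can be told from the usual scatter of repeated measurements. No supporting measurement is available to explain this result.

From the compounds shown here alone, a single pair speaks only for this one exchange, so it remains open how the number would respond at this position to a much shorter or longer chain, or to a chain ending in an amine or a carboxylic acid instead of the selenium-bearing nitrile. Compound 1 and compound 3 are still linked to compound 2 by no single change, which leaves open which of its differences goes with its number of 15 nM in this assay and whether the selenium-bearing group matters at all.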